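The source may hold more compounds than are shown below. What is called first, only, known or untested is meant among the compounds shown, and "the series" means these compounds.

Working notes on the series. In a functional assay on A549 cells (Homo sapiens) for antiproliferative activity (on this read-out lower numbers stand for an effect already at smaller amounts and higher numbers for an effect only at larger amounts of compound), compound 3 (`CO/N=C/c1cc(OC)c2c(c1OC)C(=O)C=CC2=O`) gives > 10 ug/mL as a limit and not a number. Compound 1 (`CCCCCCCCCCCCO/N=C(\CCCCCC)c1cc(OC)c2c(c1OC)C(=O)C=CC2=O`) also gives a limit, > 10 ug/mL and no number. Compound 2 (`CCCCCC/C(=N\OCCC)c1cc(OC)c2c(c1OC)C(=O)C=CC2=O`) likewise gives a limit, > 10 ug/mL and no number. The whole set therefore stands at the limit of > 10 ug/mL in this assay, at which 3 of the 3 values shown sit, and has no ranking. Going to compound 4 (`COc1cc(/C=N/OCc2ccccc2)c(OC)c2c1C(=O)C=CC2=O`), methoxy becomes benzyloxy, counted as phenyl in place of hydrogen on a saturated chain carbon bound to an oxygen on an unchanged core. Among the compounds with values here, the one measured step bearing on this, a step that the two limits leave unreadable from compound 1 to compound 2, offers no size to carry over. No shift beyond the scatter is expected in this assay in either direction. The expected step is a step that the limit leaves unreadable from compound 3 to compound 4 and remains an estimate. For compound 4 the estimated value is 12 ug/mL with an expected range from 5 ug/mL to 30 ug/mL in this read-out.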

Compound 4, concentration for half-maximal effect: > 10 ug/mL
Compound 4: only a limit was reported (the forecaster's own chance of this, stated with the estimate: 70%); the middle value lies beyond the limit too.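

Within the data shown here, compound 3 and compound 4 both give only limits in this assay, and no step between them can be read. The compounds shown leave open any ranking and any size of effect, with every value held at one limit: the limit of > 10 ug/mL in this assay, at which 4 of the 4 values shown sit.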